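The source may report more compounds than this note shows. Statements on the series, on what has been measured and on what is new or still open speak of the compounds shown alone.

In a functional assay on LNCaP cells (Homo sapiens) for cytotoxicity, read by MTT assay (a higher number here means a weaker inhibitor, a lower number a stronger inhibitor), only a thin set of results is available for this series. Compound 1 `COc1ccc2cc([C@H](C)c3nnc(SCc4c(C)cc(C)cc4C)n3-c3cccc(Cl)c3)ccc2c1` is reported as <= 400000 nM, which is a limit of the assay and not a number. Compound 3 `COc1ccc2cc([C@H](C)c3nnc(SCc4ccc(C)cc4)n3-c3ccc(F)cc3)ccc2c1` is reported as <= 400000 nM, which is also a limit. Compound 2 `COc1cccc(CSc2nnc([C@@H](C)c3ccc4cc(OC)ccc4c3)n2-c2ccc(Cl)cc2)c1`, at 162000 nM, is the only one of the three with an actual number, so it stands alone as the point of reference.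

Compound 4 `COc1ccc2cc([C@H](C)c3nnc(SCc4ccccc4)n3-c3ccc(Cl)cc3)ccc2c1` has not yet been measured. Its difference from compound 2 is hydrogen in place of methoxy on an aromatic carbon, meta to a large group, so that 3-methoxybenzyl becomes benzyl. Among the compounds with values here, no two measured compounds differ in only one place, so the data give no size for such a step. The expected step, a 1.0-fold lower number from compound 2 to compound 4 (0.01 log units; within the scatter), is therefore no larger than the usual scatter, with neither direction favoured in this assay. Compound 4 is estimated at 160000 nM, with an expected range of 70000 nM to 380000 nM.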

Compound 4, half-maximal inhibitory concentration: 50400 nM
Beside the measured number, compound 4's estimate is 3.2-fold (0.50 log units) above it, and the stated range ends above it.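

In this assay, within the data shown here, the change from 3-methoxybenzyl to benzyl gives a 3.2-fold lower number from compound 2 to compound 4 (0.51 log units; beyond the scatter), the first step that can be read. It shows that this place, meta to a large group, is not silent: with hydrogen in place of methoxy, the result moves beyond the scatter toward a stronger inhibitor, though this rests on one pair of compounds. The results for compound 1 and compound 3 are limits and not numbers, and they offer no such step: the limit of <= 400000 nM in this assay, at which 2 of the 4 values shown sit.

The compounds shown leave open whether a hydroxyl group, an amine or a carboxylic acid at this place would move the result in the same direction. They also leave open whether the step keeps its size when the rest of the molecule changes.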